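Sulfonyl substituent variation in the amide series

This account rests on a few compounds, and the source may have more. Where it says the series, first, only, none or still open, it means among the compounds named here.

Among the compounds with values here, compound 2 `CC(C(=O)NCc1ccc(C(F)(F)F)nc1N(Cc1ccccc1)S(C)(=O)=O)c1ccc(NS(C)(=O)=O)c(F)c1` sits lowest of the two numbers measured so far in an assay on CHO cells for displacement of a labelled ligand from transient receptor potential cation channel subfamily V member 1 (Homo sapiens), read by scintillation counting, with a stated time of 60 min; on this read-out higher numbers stand for weaker inhibition and lower numbers for stronger inhibition: compound 2 gives 101 nM. Within the data shown here, compound 1 `CC(C(=O)NCc1ccc(C(F)(F)F)nc1N(C)S(=O)(=O)c1ccccc1)c1ccc(NS(C)(=O)=O)c(F)c1` is its only neighbour; in this assay compound 1 gives 698 nM. Among the measured compounds shown here, the single measured step, a 6.9-fold lower number from compound 1 to compound 2 (0.84 log units; beyond the scatter), exchanges benzyl(methylsulfonyl)amino for methyl(phenylsulfonyl)amino on an aromatic carbon and so alters both substituents of that nitrogen at once. Compound 3 `CC(C(=O)NCc1ccc(C(F)(F)F)nc1N(Cc1ccccc1)S(=O)(=O)C(C)C)c1ccc(NS(C)(=O)=O)c(F)c1` is not yet measured. It differs from compound 2 by isopropyl in place of methyl on a sulfonyl sulfur: methyl leaves and isopropyl enters on the sulfonyl sulfur, the sulfonamide nitrogen being the other neighbour of that sulfur. For the measured compounds named here, only that one step touches the sulfonyl substituent, and there it was bound up with the swap of the nitrogen substituent, so it gives no clean reading for a change confined to the sulfonyl group. Going by the values given here, with no isolated precedent, the expectation for compound 3 in this assay is a step of a 1.1-fold higher number from compound 2 to compound 3 (0.04 log units; within the scatter), not beyond the scatter, in either direction. The estimate for compound 3 is 110 nM, with a range from 35 nM to 350 nM.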

Compound 3, inhibition constant: 18.1 nM
Compound 3: the middle estimate sits 6.1-fold (0.78 log units) above what was measured, and the stated range ends above it.
By their numbers in this assay, from the lowest: compound 3; then compound 2; then compound 1.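

In this assay, within the data shown here, replacing methyl with isopropyl on the sulfonyl sulfur, with the benzyl group on the sulfonamide nitrogen held constant, gives a 5.6-fold lower number from compound 2 to compound 3 (0.75 log units; beyond the scatter) and so provides the first reading confined to the sulfonyl substituent. The earlier change, a 6.9-fold lower number from compound 1 to compound 2 (0.84 log units; beyond the scatter), altered both nitrogen substituents at once, whereas this result shows that the group on the sulfonyl sulfur alone can move the binding number beyond the scatter, with compound 3 at 18.1 nM the lowest of the three compounds. Nothing available gives a measured reason for this gain.

With only methyl and isopropyl compared directly at this place, the compounds shown cannot say whether stronger inhibition would continue with tert-butyl, cyclopropyl or a longer chain such as n-butyl on the sulfonyl sulfur. From the compounds shown here alone, it also remains open whether the same methylsulfonyl to isopropylsulfonyl change would give a similar step with a nitrogen substituent other than benzyl, or in a series with a different group on the shared core.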